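Fluoro for bromo: what compound 4 may show

This account rests on a few compounds, and the source may have more. Where it says the series, first, only, none or still open, it means among the compounds named here.

Three compounds share one core and differ in the aromatic group on the carbon with a double bond to nitrogen. They were tested in a functional assay on EC9706 cells (Homo sapiens) for antiproliferative activity, read by MTT assay, with a stated time of 72 h; on this read-out higher numbers stand for weaker inhibition and lower numbers for stronger inhibition. Compound 1 (`C/C(=N\NC(=O)c1cccc(S(=O)(=O)N2CCOCC2)c1)c1ccc(F)cc1`) gives only a limit, > 100000 nM. Compound 2 (`C/C(=N\NC(=O)c1cccc(S(=O)(=O)N2CCOCC2)c1)c1cccc(O)c1`) also gives only a limit, > 100000 nM. Compound 3 (`C/C(=N\NC(=O)c1cccc(S(=O)(=O)N2CCOCC2)c1)c1cc(Br)ccc1O`) is the only one of the three with a true number, 24700 nM.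

Compound 4 (`C/C(=N\NC(=O)c1cccc(S(=O)(=O)N2CCOCC2)c1)c1cc(F)ccc1O`) changes compound 3 in one place: fluoro in place of bromo on an aromatic carbon, para to a hydroxy group (fluoro in place of bromo on an aromatic carbon).

Among the compounds with values here, two measured steps bear on this change: an at least 4.0-fold lower number from compound 1 to compound 3 (0.60 log units; beyond the scatter) and an at least 4.0-fold lower number from compound 2 to compound 3 (0.60 log units; beyond the scatter). Within the data shown here, each replaces a whole substituted phenyl group, so no measured step isolates the loss of bromo. Still, both steps show that the 5-bromo-2-hydroxyphenyl group of compound 3 gives the only measurable activity here. Compound 4 keeps the hydroxy group but gives up the bromo, so some activity may be lost, and it could even reach the limit of this assay. A modest move to a higher number is expected, a 1.8-fold higher number from compound 3 to compound 4 (0.26 log units; within the scatter). The estimate for compound 4 is 45000 nM, with an expected range of 15000 nM to 100000 nM.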

Compound 4, half-maximal inhibitory concentration: 2210 nM
Beside the measured number, compound 4's estimate is 20-fold (1.31 log units) above it; the whole stated range lies above it.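

Within the data shown here, a bromo is not required for activity at this position, para to a hydroxy group: in this assay, fluoro in its place gives an 11-fold lower number from compound 3 to compound 4 (1.05 log units; beyond the scatter), the first measured step that changes this one atom alone, and a large one. The 5-fluoro-2-hydroxyphenyl group also stands far apart from the two other aromatic groups, with an at least 45-fold lower number from compound 2 to compound 4 (1.65 log units; beyond the scatter) and an at least 45-fold lower number from compound 1 to compound 4 (1.65 log units; beyond the scatter), although each of these steps replaces a whole substituted phenyl group and so cannot be pinned on one atom. Both sizes are only minimums, because each starts from a limit and not from a true number: the limit of > 100000 nM in this assay, at which 2 of the 4 values shown sit.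

Still open, as far as these compounds go, is how chloro, methoxy or an amine at this same position would compare with fluoro and bromo, since two halogens alone cannot show a trend. The separate share of the hydroxy group is open too: no pair shown removes it alone while leaving the fluoro in place.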